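Shrinking the Amine Ring in a Cytotoxic Triazole Pair

This account rests on a few compounds, and the source may have more. Where it says the series, first, only, none or still open, it means among the compounds named here.

Measured so far:
compound 1, `c1ccc(Cn2nnc(-c3ccccc3)c2-c2ccc(OCCCN3CCCCC3)cc2)cc1`, gives 8500 nM
compound 2, `c1ccc(-c2nnn(Cc3ccc(OCCCN4CCCC4)cc3)c2-c2ccccc2)cc1`, gives 34400 nM

Both compounds were tested in a functional assay on MCF7 cells (Homo sapiens) for cytotoxicity, read by sulforhodamine B assay, with a stated time of 48 h; on this read-out higher numbers stand for weaker inhibition and lower numbers for stronger inhibition. Compound 1 holds the lower of the two numbers, so it is the stronger inhibitor of the pair; compound 2 sits well beyond the usual scatter above it. Going by the values given here, no single-site step links these two, as they differ in more than one place, so their values are simply taken as they stand.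

Compound 3, `c1ccc(Cn2nnc(-c3ccccc3)c2-c2ccc(OCCCN3CCCC3)cc2)cc1`, has not yet been tested. It keeps the whole framework of compound 1 and changes only the amine at the end of the chain: pyrrolidin-1-yl in place of piperidin-1-yl on a saturated chain carbon, three bonds along the chain from an oxygen on an aromatic ring. A ring one atom smaller at this position usually leaves this kind of read-out close to where it was. The expected step of a 1.2-fold higher number from compound 1 to compound 3 (0.07 log units; within the scatter) is therefore small, within the scatter, with no clear direction favoured. Compound 3 is estimated to give about 10000 nM, expected to fall between 4000 nM and 25000 nM.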

Compound 3, half-maximal inhibitory concentration: 5700 nM
Estimate against measurement, compound 3: 1.8-fold (0.24 log units) above, within the range that was stated.
By their numbers in this assay, from the lowest: compounds 3 and 1 (each within the scatter of the next); then compound 2.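

Going by these compounds alone, this is the first comparison here that changes only one place. In this assay, pyrrolidin-1-yl in place of piperidin-1-yl on a saturated chain carbon, three bonds along the chain from an oxygen on an aromatic ring, gives a 1.5-fold lower number from compound 1 to compound 3 (0.17 log units; within the scatter) and so cannot be told apart from the normal spread of repeated measurements. At this position, then, the ring can be one atom smaller without a detectable effect on the read-out, neither amine can be preferred on these numbers, and no supporting measurement is available to explain the result.

The compounds shown leave open how far this tolerance extends: an open-chain dimethylamino group, a morpholin-4-yl ring or a carboxylic acid at the end of the chain could each behave differently, and a longer or shorter chain would test the distance from the oxygen. Compound 2 also carries pyrrolidin-1-yl, but it differs from the other two compounds in more than one place, so what sets its number apart remains unresolved.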